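The compounds below may be only part of what the source reports. "The series", "measured", "known", "first", "only" and "open" are said of these compounds alone.

In an ADME assay on microsomes from liver (Rattus norvegicus) for metabolic stability (on this read-out lower numbers stand for a shorter-lived compound and higher numbers for a longer-lived compound), compound 1 `CN1C(=O)COc2ccc(Nc3cc4c(cn3)ncn4CC3CC3)cc21` gives 0.417 h as its half-life, and compound 2 `CN1C(=O)COc2nc(Nc3cc4c(cn3)ncn4CC3CC3)ccc21` gives 0.65 h as its half-life, two values within the usual scatter of each other. Compound 3 `CN1C(=O)COc2cc(Nc3cc4c(cn3)ncn4CC3CC3)cnc21` gives > 1.66 h as its reading, which is a limit and not a number. Compound 3 thus stands at the limit of > 1.66 h in this assay, at which 1 of the 3 values shown sits, and offers no exact half-life as a starting point.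

Compound 4 `Cc1nc(Nc2cnc3c(c2)OCC(=O)N3C)cc2c1ncn2CC1CC1` differs from compound 3 by methyl in place of hydrogen on an aromatic carbon next to the ring nitrogen. For the measured compounds named here, no two measured compounds differ in one place only, so the data give no direct measure of what such a change does. In this assay no step beyond the usual scatter is expected in either direction, and the estimated change is an at least 1.0-fold lower number from compound 3 to compound 4 (0.01 log units; that floor lies within the scatter) on this reading. A result that is again only a limit is expected to be quite possible. For compound 4 the estimated half-life is 1.6 h with an expected range from 0.7 h to 3.5 h across repeated measurements.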

Compound 4, half-life: > 1.66 h
Compound 4 was reported as a limit; the forecaster's own chance of this, stated with the estimate: 45%; at least 1.0-fold (0.01 log units) between middle value and limit.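

In this assay compound 4 gives > 1.66 h, which is a limit and not a number. For the compounds shown here, the reading of compound 3 is a limit as well, so no step between compound 3 and compound 4 can be read: the limit of > 1.66 h in this assay, at which 2 of the 4 values shown sit. The compounds shown leave open the exact half-life of either compound and what methyl in place of hydrogen on an aromatic carbon does to it.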